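Adding an open chain to compound 2

The compounds below may be only part of what the source reports. "The series", "measured", "known", "first", "only" and "open" are said of these compounds alone.

In an ADME assay for permeability, using PAMPA, with a stated time of 4 h, at pH 5.5 (a higher number here means that the compound crosses the layer faster, a lower number that the compound crosses the layer more slowly), compound 2 (`CN(C[C@H]1Cc2ncccc2CN1)[C@H]1CCCc2cccnc21`) gives 460 nm/s and compound 3 (`CN(C[C@@H]1Cc2ncccc2CN1)[C@H]1CCCc2cccnc21`) gives 230 nm/s on the same scale, two values within the scatter of each other. Both stand far above compound 1 (`NCCCCN(C[C@H]1Cc2nccnc2CN1)[C@H]1CCCc2cccnc21`), which gives 2 nm/s in the same test.

Compound 4 (`NC(=O)NC/C=C/CN(C[C@H]1Cc2ncccc2CN1)[C@H]1CCCc2cccnc21`) differs from compound 2 by a single change (a group of 7 heavy atoms (4 carbon, 2 nitrogen, 1 oxygen; no ring) in place of a hydrogen atom, on a saturated chain carbon bound to an amine nitrogen) in which a group with no ring takes the place of a hydrogen atom. Among the measured compounds shown here, the only measured step is a 2.0-fold lower number from compound 2 to compound 3 (0.30 log units; within the scatter) and it reflects the fact that compounds 2 and 3 differ only in the configuration as drawn so it gives no size for a change of this kind. No measurement here isolates the new group. For the measured compounds named here, the nearest guide is compound 1 at 2 nm/s as the one measured compound that carries a long open chain, although this single comparison is weak evidence. A clear fall in this assay beyond the scatter is therefore expected, probably stopping short of the value of compound 1. The estimated change is a 31-fold lower number from compound 2 to compound 4 (1.49 log units; beyond the scatter) in this test. For compound 4 the expected value is 15 nm/s with an estimated range from 3 nm/s to 80 nm/s in this test.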

Compound 4, apparent permeability: 6 nm/s
Beside the measured number, compound 4's estimate is 2.5-fold (0.40 log units) above it, within the range that was stated.
By their numbers in this assay, from the lowest: compound 1; then compound 4; then compounds 3 and 2 (each within the scatter of the next).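

At the saturated chain carbon bound to an amine nitrogen, a group of 7 heavy atoms (4 carbon, 2 nitrogen, 1 oxygen; no ring) in place of a hydrogen atom gives, in this assay, a 77-fold lower number from compound 2 to compound 4 (1.88 log units; beyond the scatter). Among the compounds shown here, the only earlier step, a 2.0-fold lower number from compound 2 to compound 3 (0.30 log units; within the scatter), involved configuration alone, so this is the first measured size for a change at this place, and it shows that one open chain added here can move the number far beyond the scatter. The step gives the size of the fall but not its origin, and nothing measured here bears on why the number drops.

For the compounds shown here, with only one group tested at this place, the step cannot separate the effect of the chain's length from that of its end, so a shorter chain, or a chain of the same length ending in a hydroxyl group or a carboxylic acid, would be needed to tell them apart. From the compounds shown here alone, it also remains open whether the same group would give a similar step on compound 3, which has the other configuration at the saturated ring carbon.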